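From tert-butyl to trifluoromethoxy on the shared core

The source may report more compounds than this note shows. Statements on the series, on what has been measured and on what is new or still open speak of the compounds shown alone.

Measured in a functional assay on CWR22R cells (Homo sapiens) for antiproliferative activity, with a stated time of 96 h; on this read-out higher numbers stand for weaker inhibition and lower numbers for stronger inhibition:
Compound 1 `Cc1cc(=O)oc2cc(OCC(=O)c3ccc(C(C)(C)C)cc3)ccc12`: 22300 nM
Compound 2 `Cc1cc(=O)oc2cc(OCC(=O)c3cccc(C(F)(F)F)c3)ccc12`: > 100000 nM (a limit of the assay)

In this assay, among the compounds with values here, compound 1 gives 22300 nM, the only exact number so far. Compound 2 is reported only as a limit, > 100000 nM. Compound 3 `Cc1cc(=O)oc2cc(OCC(=O)c3ccc(OC(F)(F)F)cc3)ccc12` carries trifluoromethoxy in place of tert-butyl on an aromatic carbon, para to a large group (trifluoromethoxy in place of tert-butyl on an aromatic carbon). Within the data shown here, no measured pair shows this change directly. A moderate step toward weaker inhibition is expected in this assay, a cautious expectation resting only on compound 2, whose limit is > 100000 nM. The estimated step is a 2.0-fold higher number from compound 1 to compound 3 (0.30 log units; within the scatter). For compound 3 the expected value is 45000 nM, with an estimated range of 15000 nM to 100000 nM.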

Compound 3, half-maximal inhibitory concentration: > 100000 nM
Compound 3 gave a limit, no number (the forecaster's own chance of this, stated with the estimate: 30%); middle value at least 2.2-fold (0.34 log units) from the limit.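

In this assay, trifluoromethoxy in place of tert-butyl on an aromatic carbon, para to a large group, gives the one direct comparison at this position among the compounds shown: an at least 4.4-fold higher number from compound 1 to compound 3 (0.65 log units; beyond the scatter). The value of compound 3 is a limit of the assay, > 100000 nM. How much larger the step is cannot be read, since the reading stops at the edge of the assay: the limit of > 100000 nM in this assay, at which 2 of the 3 values shown sit.

Going by these compounds, whether an amine, a carboxylic acid or a longer alkyl chain in place of tert-butyl would give an exact number in this assay remains open.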